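A Methoxy-to-Chloro Swap on an Aromatic Ring

The source may hold more compounds than are shown below. What is called first, only, known or untested is meant among the compounds shown, and "the series" means these compounds.

In a functional assay on L1210 cells (Mus musculus) for inhibition, read by cell counting, with a stated time of 48 h (a higher number here means a weaker inhibitor, a lower number a stronger inhibitor), the read-out is the half-maximal inhibitory concentration. There, compound 1 (`CCN(CC)CN1C(=O)/C(=N/NC(=S)Nc2ccc(Cl)cc2)c2ccccc21`) gives 11000 nM as its reading. Compound 2 (`CCN(CC)CN1C(=O)/C(=N/NC(=S)Nc2ccc(OC)cc2)c2cc(Cl)ccc21`) gives 11000 nM as its reading, so it stands level with compound 1 at the digits available.

The next candidate is compound 3 (`CCN(CC)CN1C(=O)/C(=N/NC(=S)Nc2ccc(Cl)cc2)c2cc(Cl)ccc21`), which has not yet been measured. It differs from compound 2 in one place, on a six-membered aromatic ring of carbon only, para to a large group (chloro in place of methoxy on an aromatic carbon). This turns 4-methoxyphenyl into 4-chlorophenyl.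

Going by the values given here, no pair of measured compounds differing in a single place is available as a guide, so any forecast rests on thin evidence. The two level readings give no sign of a large swing. A small move toward stronger inhibition is therefore expected, probably not beyond the usual scatter. The estimated size of this move is a 1.4-fold lower number from compound 2 to compound 3 (0.14 log units; within the scatter) in this assay as a working figure. The estimate for compound 3 is 8000 nM with 3000 nM and 20000 nM as the ends of its expected range.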

Compound 3, half-maximal inhibitory concentration: > 125000 nM
Compound 3: no number, only a limit; the forecaster's own chance of this, stated with the estimate: 5%; middle value at least 15-fold (1.19 log units) from the limit.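

In this assay compound 3 gives only a limit of the assay, not a number: the limit of > 125000 nM in this assay, at which 1 of the 3 values shown sits. Two different single changes lead to this compound, and both steps are large: chloro in place of methoxy gives an at least 11-fold higher number from compound 2 to compound 3 (1.05 log units; beyond the scatter), and chloro in place of hydrogen on an aromatic carbon gives an at least 11-fold higher number from compound 1 to compound 3 (1.05 log units; beyond the scatter). The outcome of either change therefore depends on the rest of the molecule: the 4-chlorophenyl group also stands in compound 1, the chloro on the shared core also stands in compound 2, and among these three only compound 3, which carries both, reaches the limit.

The limit leaves the true size of both steps open, and three compounds cannot show whether this dependence holds beyond them. From the compounds shown here alone, it is also open whether another group in the same place on the core of compound 3, such as fluoro, methyl or a dimethylamino group, would keep the reading near that of compound 2 or leave it at the limit.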